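A Methoxy Group Added to Compound 2

The source may report more compounds than this note shows. Statements on the series, on what has been measured and on what is new or still open speak of the compounds shown alone.

Comparing compounds that differ in a single place is a common way to learn what one group contributes. In a functional assay on MCF-10A cells (Homo sapiens) for antiproliferative activity, with a stated time of 48 h (on this read-out higher numbers stand for an effect only at larger amounts of compound and lower numbers for an effect already at smaller amounts), compound 1 (`COc1ccc2nc(C)cc(NCc3cccc(-c4ccccc4)c3)c2c1`) gives 3100 nM and compound 2 (`Cc1cc(NCc2ccc(F)cc2)c2ccccc2n1`) gives 20100 nM as the higher of the two numbers, a gap beyond the usual scatter. Going by the values given here, compound 3 (`COc1ccc2c(NCc3ccc(F)cc3)cc(C)nc2c1`) has no measurement yet. It is compound 2 with one change (methoxy in place of hydrogen on an aromatic carbon): methoxy in place of hydrogen on an aromatic carbon of the shared core. Among the compounds with values here, no measured pair differs in only one place, so no direct precedent exists for this change. Compound 1 also carries a methoxy group and has the lower number at 3100 nM but it differs from compound 2 in other ways too, so it offers only a weak hint. In this assay the expected result is a small drop in the number (a 1.7-fold lower number from compound 2 to compound 3 (0.22 log units; within the scatter)) that probably stays within the usual scatter. Compound 3 is estimated at 12000 nM and expected to fall between 4000 nM and 30000 nM.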

Compound 3, half-maximal effective concentration: 15900 nM
Compound 3: the middle estimate sits 1.3-fold (0.12 log units) below what was measured, and the stated range covers the measured number.
By their numbers in this assay, from the lowest: compound 1; then compounds 3 and 2 (each within the scatter of the next).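

In this assay, going by these compounds alone, this is the first direct reading of the change, and it gives a 1.3-fold lower number from compound 2 to compound 3 (0.10 log units; within the scatter), so methoxy in place of hydrogen at this place on the shared core, meta to a fused ring and para to a fused ring, leaves the number unchanged as far as repeated measurements can tell. Within the data shown here, the weak hint from compound 1, which also carries a methoxy group, finds no support in this pair, since at this position the methoxy step alone does not move the number beyond the usual scatter. There is no measured evidence at hand that bears on the reason for this result.

One step at one position cannot tell whether methoxy would behave the same way elsewhere on the shared core, or whether a different group at this place, such as an amine, a carboxylic acid or a longer chain, would shift the number beyond the scatter. As far as these compounds go, it also remains open whether methoxy would matter more alongside the other features of compound 1, which differs from compound 2 in more than one place.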